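The source may report more compounds than this note shows. Statements on the series, on what has been measured and on what is new or still open speak of the compounds shown alone.

Measured compounds in a functional assay on HepG2 cells (Homo sapiens) for cytotoxicity, with a stated time of 24 h; a lower number here means a stronger inhibitor, a higher number a weaker inhibitor:
- Compound 1 `Cc1ccc(C(=O)N/N=C/c2cc(I)cc(I)c2O)cc1`: compound 1 gives > 25000 nM, which is a limit of the assay and not a number.
- Compound 2 `O=C(N/N=C/c1cc(I)cc(I)c1O)c1ccc(O)cc1`: compound 2 gives 19200 nM.
- Compound 3 `O=C(N/N=C/c1cc(I)cc(I)c1O)c1ccc(C(F)(F)F)cc1`: compound 3 gives 11700 nM.

Compound 3 has the lowest of the two numbers in this assay; its nearest neighbour is compound 2, and the gap a 1.6-fold lower number from compound 2 to compound 3 (0.22 log units; within the scatter) lies within the scatter. The step of an at least 2.1-fold lower number from compound 1 to compound 3 (0.32 log units; beyond the scatter) is at least modest, but it rests on the limit (the limit of > 25000 nM in this assay, at which 1 of the 3 values shown sits). The step of an at least 1.3-fold lower number from compound 1 to compound 2 (0.11 log units; that floor lies within the scatter) rests on that same limit.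

Compound 4 `O=C(N/N=C/c1cc(I)cc(I)c1O)c1ccc([N+](=O)[O-])cc1` is not yet measured. It differs from compound 3 in one place: nitro in place of trifluoromethyl on an aromatic carbon. Among the compounds with values here, no measured step replaces trifluoromethyl by nitro, so only the earlier swaps on the same aromatic carbon inform the expectation: one of them, a 1.6-fold lower number from compound 2 to compound 3 (0.22 log units; within the scatter), stayed within the scatter, and the other, an at least 2.1-fold lower number from compound 1 to compound 3 (0.32 log units; beyond the scatter), was at least modest. For compound 4 in this assay the expected step is a 1.1-fold lower number from compound 3 to compound 4 (0.03 log units; within the scatter), not beyond the scatter. Compound 4 is therefore estimated at 11000 nM, with a range from 4500 nM to 25000 nM.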

Compound 4, half-maximal inhibitory concentration: 24700 nM
Compound 4: middle estimate off by 2.2-fold (0.35 log units), on the low side; the measured number falls inside the stated range.
By their numbers in this assay, from the lowest: compounds 3, 2 and 4 (each within the scatter of the next, the first and the last beyond it). At a limit, above all of these: compound 1.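

In this assay, within the data shown here, the aromatic carbon para to a large group gives the first direct comparison of trifluoromethyl with nitro, and the two groups are separated by a modest step (a 2.1-fold higher number from compound 3 to compound 4 (0.32 log units; beyond the scatter)). Nitro and hydroxy are not separated at this carbon (a 1.3-fold higher number from compound 2 to compound 4 (0.11 log units; within the scatter)), and neither are hydroxy and trifluoromethyl (a 1.6-fold lower number from compound 2 to compound 3 (0.22 log units; within the scatter)), so only the trifluoromethyl and nitro pair is resolved among these three measured numbers. The step of an at least 1.0-fold lower number from compound 1 to compound 4 (0.00 log units; that floor lies within the scatter) cannot be read. Compound 1 gives a limit and not a number: the limit of > 25000 nM in this assay, at which 1 of the 4 values shown sits.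

Going by these compounds, it remains open whether an amine or a carboxylic acid on this aromatic carbon would extend the modest spread seen so far. The compounds shown also leave open whether the difference between compound 3 and compound 4 would persist with a changed iodine substitution on the shared core.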